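Aryl variation on the isoxazole of the nitrobenzyl-piperidine triazole series

The source may report more compounds than this note shows. Statements on the series, on what has been measured and on what is new or still open speak of the compounds shown alone.

In a functional assay on MDA-MB-231 cells (Homo sapiens) for cytotoxicity, with a stated time of 48 h (a lower number here means a stronger inhibitor, a higher number a weaker inhibitor), compound 1 `COc1ccc(-c2cc(COC(Cc3cn(C4CCN(Cc5ccc([N+](=O)[O-])cc5)CC4)nn3)c3ccc(Br)cc3)on2)cc1` gives only a limit, > 25000 nM. Compound 2 `O=[N+]([O-])c1ccc(CN2CCC(n3cc(CC(OCc4cc(-c5cccc(Br)c5)no4)c4ccc(Br)cc4)nn3)CC2)cc1` likewise gives only a limit in this assay, > 25000 nM. Compound 3 `N#Cc1cccc(-c2cc(COC(Cc3cn(C4CCN(Cc5ccc([N+](=O)[O-])cc5)CC4)nn3)c3ccc(Br)cc3)on2)c1` also stands at a limit in this assay, > 25000 nM. Among the measured compounds shown here, since every value is a limit, the steps cannot be read: a step that the two limits leave unreadable from compound 1 to compound 2, a step that the two limits leave unreadable from compound 1 to compound 3 and a step that the two limits leave unreadable from compound 2 to compound 3 all remain unreadable, and the only thing the numbers show is the limit of > 25000 nM in this assay, at which 3 of the 3 values shown sit. Compound 3 therefore stands at that limit, no better and no worse than the other two as far as the assay can tell.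

Compound 4 `O=[N+]([O-])c1ccc(CN2CCC(n3cc(CC(OCc4cc(-c5ccccc5Br)no4)c4ccc(Br)cc4)nn3)CC2)cc1` differs from compound 3 in one place: 2-bromophenyl in place of 3-cyanophenyl on an aromatic carbon. For the measured compounds named here, no measured step bears on this change with a readable size, and the three aryl variants so far all sit at the limit. The expected step is therefore a step that the limit leaves unreadable from compound 3 to compound 4, that is, no change that the assay could resolve. Compound 4 is estimated to give 40000 nM in this assay, within 25000 nM to 150000 nM, most likely reported again only as a limit.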

Compound 4, half-maximal inhibitory concentration: > 25000 nM
Compound 4: only a limit was reported (the forecaster's own chance of this, stated with the estimate: 90%); the middle value is on the limit's open side.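

Among the compounds shown here, compound 4 gives only a limit in this assay and, like compound 1, compound 2 and compound 3, allows no step to be read: the limit of > 25000 nM in this assay, at which 4 of the 4 values shown sit. The compounds shown leave open whether any aryl group at this place on the shared core gives a readable value in this assay at all.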